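A few compounds are considered here, and "the series" means these few. Any claim that something is new, unique, unknown or untested is made for them only; others in the source may bear on it.

Measured so far:
Compound 1, `COc1cc(C)cc(-c2c(-c3ccnc(-c4ccc(C(C)=O)cc4)c3)cnn2CC#N)c1`, gives 100% in a functional assay on TK-10 cells (Homo sapiens) for cytotoxicity, read by sulforhodamine B assay, with a stated time of 48 h, tested at 0.01 uM; a higher number here means a weaker effect of the compound at the concentration tested, a lower number a stronger effect.
Compound 2, `Cc1cc(O)cc(-c2nn(CC#N)cc2-c2ccnc(-c3ccc(Oc4ccccc4)cc3)c2)c1`, gives 99% in this assay.
Compound 3, `COc1cc(C)cc(-c2nn(CC#N)cc2-c2ccnc(-c3ccc(N(C)C)cc3)c2)c1`, gives 119% in this assay.

Among these three numbers compound 3 stands highest. Its nearest neighbour is compound 1, whose number is lower by an amount beyond the scatter, and the furthest is compound 2, whose number is lower by a slightly larger amount, also beyond the scatter. All three compounds, then, show little effect at the concentration tested, and compound 3 shows the least of the three.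

The next compound is compound 4, `Cc1cc(O)cc(-c2nn(CC#N)cc2-c2ccnc(-c3ccc(N(C)C)cc3)c2)c1`, which has not yet been measured in this assay. It differs from compound 3 in one place: hydrogen in place of methyl on an oxygen on an aromatic ring. Among the measured compounds shown here, no step between two measured compounds shows this change on its own, so the account rests only on what the three numbers show. Compound 2, which carries the hydroxy group, and compound 1, which carries the methoxy group, both sit close to the top of the scale, and compound 3 sits a little higher still.

On this basis the step in this assay from compound 3 to compound 4 is expected to be a number 11 percentage points lower from compound 3 to compound 4 (beyond the scatter), that is, none beyond the scatter. Compound 4 is therefore estimated at 108%, with a range from 92% to 122%.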

Compound 4, a percentage reported as activity, at one concentration (the size of the read-out at that concentration, not a potency): 107%
For compound 4 the middle estimate is 1 percentage points above the measured one, and the stated range covers the measured number.
By their numbers in this assay, from the lowest: compounds 2, 1 and 4 (each within the scatter of the next); then compound 3.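

In this assay, among the compounds shown here, the swap of methoxy for hydroxy, which turns the 3-methoxy-5-methylphenyl group into 3-hydroxy-5-methylphenyl while the dimethylamino group stays in place, gives a number 12 percentage points lower from compound 3 to compound 4 (beyond the scatter) and is the first reading of this change on its own; it is a modest step, and it shows that this oxygen substituent can move the number beyond the scatter. With the hydroxy group held, dimethylamino in place of phenoxy on an aromatic carbon gives a number 8 percentage points higher from compound 2 to compound 4 (within the scatter) and so does not separate these two compounds in this assay, which means that this second change, unlike the first, shows no effect that can be told from the scatter. Nothing measured here gives a reason for either step.

For the compounds shown here, the change from methoxy to hydroxy is seen only with the dimethylamino group present, so it remains open whether the same step would appear with phenoxy or acetyl at the other end of the molecule. On these data alone, it also remains open how an ethoxy group or an amine at this place on the aromatic ring would read in this assay at the concentration tested.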